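Putting (azetidin-1-yl)methyl in place of chloro on compound 3

A few compounds are considered here, and "the series" means these few. Any claim that something is new, unique, unknown or untested is made for them only; others in the source may bear on it.

Of the compounds shown here, three have been measured in an ADME assay on a cell-free system (plasma, Rattus norvegicus) for protein binding, so far.

- compound 1 `CNc1nccc(N2CC[C@H](NC(=O)Nc3ccc(CN(C)C)c(C(F)(F)F)c3)C2)n1` gives 91%
- compound 2 `CNc1nccc(N2CC[C@H](NC(=O)Nc3cc(OC)cc(OC)c3)C2)n1` gives 96.7%
- compound 3 `CNc1nccc(N2CC[C@H](NC(=O)Nc3ccc(Cl)c(C(F)(F)F)c3)C2)n1` gives 99.7%

Compound 3, at 99.7%, has the lowest unbound fraction of the three. Its nearest neighbour on these numbers is compound 2, at 96.7%, and compound 1 lies furthest away, at 91%.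

The next compound is compound 4 `CNc1nccc(N2CC[C@H](NC(=O)Nc3ccc(CN4CCC4)c(C(F)(F)F)c3)C2)n1`, which carries (azetidin-1-yl)methyl in place of chloro on an aromatic carbon, ortho to a trifluoromethyl group and para to a large group.

Within the data shown here, one measured step bears on this change. It is a 30-fold lower unbound fraction from compound 1 to compound 3 (1.48 log units; beyond the scatter), in which chloro took the place of (dimethylamino)methyl on an aromatic carbon. Among the measured compounds shown here, the new change runs nearly the reverse way, although the entering group is (azetidin-1-yl)methyl and not (dimethylamino)methyl, and no measurement yet compares those two groups.

A large step toward a higher unbound fraction is therefore expected in this assay, of about the size of the measured one. The expected step is a 33-fold higher unbound fraction from compound 3 to compound 4 (1.52 log units; beyond the scatter), and it is only an estimate. For compound 4 the estimated value is 90%, with an expected range from 80% to 96%.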

Compound 4, plasma protein binding: 89.2%
For compound 4 the middle estimate is 1.1-fold (0.03 log units) (unbound fraction) below the measured one, and the stated range covers the measured number.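

In this assay, a 36-fold higher unbound fraction from compound 3 to compound 4 (1.56 log units; beyond the scatter) stands alongside a 30-fold lower unbound fraction from compound 1 to compound 3 (1.48 log units; beyond the scatter), so the large gap between chloro and an aminomethyl group on this aromatic carbon, ortho to a trifluoromethyl group, now rests on two different entering groups rather than one. Among these compounds, the compounds also give the first direct comparison of (azetidin-1-yl)methyl and (dimethylamino)methyl at this place: azetidin-1-yl in place of dimethylamino gives a 1.2-fold higher unbound fraction from compound 1 to compound 4 (0.08 log units; within the scatter), so the four-membered ring and the open dimethylamino group cannot be told apart in this assay in this pair. Nothing at hand gives a measured reason for the gap between chloro and these two groups.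

The compounds shown leave open how far this equivalence extends, since a larger ring such as (piperidin-1-yl)methyl or (morpholin-4-yl)methyl, or a primary aminomethyl group, could behave differently at this place. They also do not separate the contribution of the ring nitrogen from that of the added carbon atoms, which an ether such as methoxymethyl on the same aromatic carbon would begin to address.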